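Furan in place of thiophene on the sulfonyl group

The source may report more compounds than this note shows. Statements on the series, on what has been measured and on what is new or still open speak of the compounds shown alone.

Of the compounds shown here, three sharing one core have been tested in a functional assay on the whole organism (strain Jcl:SD) for inhibition, with Rattus norvegicus as the target, with stated times of 3 min and 3 h, at a dose of 1 mg/kg by the intravenous route; on this read-out higher numbers stand for more inhibition at the one dose given (going by the name of the read-out) and lower numbers for less inhibition. Compound 1 `CNCc1cc(-c2cccnc2F)n(S(=O)(=O)c2cccc(F)c2)c1` carries a 3-fluorophenyl on the sulfonyl sulfur and gives 99%. Compound 2 `CNCc1cc(-c2cccnc2F)n(S(=O)(=O)c2ccsc2)c1` carries thiophen-3-yl at the same place and gives 98%. Compound 3 `CNCc1cc(-c2cccnc2F)n(S(=O)(=O)c2cccs2)c1` carries thiophen-2-yl there and gives 96%. On the bare numbers compound 3 has the lowest of the three, yet its gaps to both others lie within the scatter: a number 3 percentage points lower from compound 1 to compound 3 (within the scatter) and a number 2 percentage points lower from compound 2 to compound 3 (within the scatter). The same holds for a number 1 percentage points lower from compound 1 to compound 2 (within the scatter). Taken together, the three groups tried on the sulfonyl sulfur have left the inhibition close to the top of the scale, with no difference that can be trusted.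

Compound 4 `CNCc1cc(-c2cccnc2F)n(S(=O)(=O)c2ccco2)c1` is reached from compound 3 by a single exchange: furan-2-yl in place of thiophen-2-yl on a sulfonyl sulfur. All three earlier steps at this position bear on it, and each moved the read-out by only a few points, never beyond the scatter. A comparable outcome is expected here, with no step beyond the scatter in this assay. The expected change is a number 1 percentage points lower from compound 3 to compound 4 (within the scatter). Compound 4 is therefore estimated to give 95%, with a likely range from 86% to 99%.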

Compound 4, a percentage reported as inhibition, in the whole organism at one dose (the size of the read-out at that dose, not a potency): 74%
The estimate for compound 4 lay 21 percentage points above the measured number; measured number outside the range, below it.
By their numbers in this assay, from the lowest: compound 4; then compounds 3, 2 and 1 (each within the scatter of the next).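

In this assay the group on the sulfonyl sulfur turns out to matter: furan-2-yl in place of thiophen-2-yl gives a clear loss (a number 22 percentage points lower from compound 3 to compound 4 (beyond the scatter)), even though both groups have 5 heavy atoms and one five-membered aromatic ring with 1 hetero atom, and the exchange amounts to oxygen in place of sulfur in that ring. The comparisons with the other two groups point the same way (a number 24 percentage points lower from compound 2 to compound 4 (beyond the scatter); a number 25 percentage points lower from compound 1 to compound 4 (beyond the scatter)), so compound 4 stands apart from three compounds that lie within the scatter of their neighbours, and a small change in the ring was enough to separate them. Nothing available gives a reason for this drop.

The compounds shown leave open whether furan-3-yl, the oxygen counterpart of thiophen-3-yl, would share the lower number of compound 4 or stay close to compound 2. Also open, as far as these compounds go, is where a ring with a second hetero atom, such as thiazol-2-yl or oxazol-2-yl, would fall, and whether a lower dose would reveal differences among the three compounds now close to the top of the scale.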